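Taking a Methyl off a Saturated Ring Carbon

A few compounds are considered here, and "the series" means these few. Any claim that something is new, unique, unknown or untested is made for them only; others in the source may bear on it.

The three measured compounds, with their results in an ADME assay on microsomes from liver (Mus musculus) for metabolic stability, read by LC-MS, using NADPH, with a stated time of 10 min, tested at 0.1 uM; on this read-out lower numbers stand for slow clearance and higher numbers for fast clearance:

compound 1, `CC1SC(c2cccc(C(=O)NCCCCc3ccccc3)c2)N(c2ccc(C3CC3)cc2)C1=O`, gives 3210 mL.min-1.g-1
compound 2, `C#Cc1cc(C(=O)NCCCCc2ccccc2)cc(C2SCC(=O)N2c2ccccc2OC)c1`, gives 2490 mL.min-1.g-1
compound 3, `O=C(NCCCCn1cccn1)c1cccc(C2SCC(=O)N2c2cc(F)ccn2)c1`, gives 397 mL.min-1.g-1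

Compound 1 stands at the highest of the three numbers in this assay. Compound 2 lies nearest, with a number lower by a margin that falls within the scatter of repeated measurements, so the two cannot be told apart. Compound 3 lies furthest, with a number lower by a margin that is beyond the scatter.

The unmeasured compound 4, `O=C(NCCCCc1ccccc1)c1cccc(C2SCC(=O)N2c2ccc(C3CC3)cc2)c1`, is compound 1 with one change: hydrogen in place of methyl on a saturated ring carbon. The rest of the molecule, from the large amide-bearing side chain to the 4-cyclopropylphenyl group, is kept.

Among the measured compounds shown here, no measured pair among the three compounds differs by this change alone, so the size of the step has no direct precedent here. A difference of one carbon in a molecule of this size is expected to leave the number for compound 4 close to that of compound 1, and the step of a 1.1-fold lower number from compound 1 to compound 4 (0.06 log units; within the scatter) is estimated to fall within the scatter, with no clear direction. In this assay compound 4 is therefore expected to give about 2800 mL.min-1.g-1, within a range of 1400 mL.min-1.g-1 to 5600 mL.min-1.g-1.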

Compound 4, intrinsic clearance in microsomes: 2960 mL.min-1.g-1
The estimate for compound 4 lay 1.1-fold (0.02 log units) below the measured number; low and high end bracket the measured number.
By their numbers in this assay, from the lowest: compound 3; then compounds 2, 4 and 1 (each within the scatter of the next).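

In this assay, the step is a 1.1-fold lower number from compound 1 to compound 4 (0.04 log units; within the scatter), which lies within the scatter, so compound 1 and compound 4 cannot be told apart and the methyl on this saturated ring carbon, next to the ring sulfur, makes no readable difference to intrinsic clearance in this pair. Among the compounds shown here, this is the first direct reading at this position, as none of the earlier compounds formed a pair differing in one place, and with the 4-cyclopropylphenyl group and the large group held constant, the comparison isolates methyl against hydrogen at this carbon. Nothing available here explains the result, which therefore stands as an observation on this single pair alone.

The compounds shown leave open whether a different group on this carbon, such as an ethyl, a hydroxymethyl, a carboxylic acid or an amine, would also leave the clearance number within the scatter of compound 4. They also leave open whether hydrogen and methyl would remain indistinguishable here if a group other than 4-cyclopropylphenyl stood on the neighbouring ring atom that bears it.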